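The compounds below may be only part of what the source reports. "The series", "measured", "known", "first", "only" and "open" are said of these compounds alone.

Working notes on the series.

Compound 1 `Cc1ccccc1-n1nc(C)c2c1NC(=O)[C@H](C)S[C@@H]2c1ccc(/C=C/c2ccccc2)cc1` carries a 2-phenylethenyl group and in an assay on isolated protein for agonist activity at Bile acid receptor (Homo sapiens), read by AlphaScreen, with a stated time of 30 min (on this read-out higher numbers stand for an effect only at larger amounts of compound and lower numbers for an effect already at smaller amounts), compound 1 gives "not active" (no number reported), so no number places it on the scale. Among the measured compounds shown here, compound 2 `Cc1nn(-c2ccccc2C(C)C)c2c1[C@@H](c1ccc(Oc3ccccc3)cc1)S[C@@H](C)C(=O)N2` gives 1900 nM and compound 3 `CCc1ccccc1-n1nc(C)c2c1NC(=O)[C@H](C)S[C@@H]2c1ccc(Oc2ccccc2)cc1` gives 1100 nM; the only single-point step, a 1.7-fold lower number from compound 2 to compound 3 (0.24 log units; within the scatter), changes a different part of the structure and so does not speak to the change from compound 1 to compound 4 `COc1cccc(-c2ccc([C@H]3S[C@@H](C)C(=O)Nc4c3c(C)nn4-c3ccccc3C)cc2)c1`, which is 3-methoxyphenyl in place of 2-phenylethenyl on an aromatic carbon. For the measured compounds named here, no measured pair separates 2-phenylethenyl from 3-methoxyphenyl; the values of compound 2 and compound 3 show only that an aromatic ring joined through oxygen at this position gives measurable activity. Compound 4 is therefore expected to be measurable but weak, with an estimate of 4000 nM spanning 800 nM to 20000 nM, and a real chance that only a limit is returned.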

Compound 4, half-maximal effective concentration: 1800 nM
Compound 4: middle estimate off by 2.2-fold (0.35 log units), on the high side; the range from low to high includes it.
By their numbers in this assay, from the lowest: compounds 3, 4 and 2 (each within the scatter of the next).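

In this assay, among the compounds shown here, compound 1 gives "not active" (no number reported) and compound 4 gives 1800 nM so no step between compound 1 and compound 4 can be read. Going by these compounds, how 3-methoxyphenyl compares with 2-phenylethenyl on a numerical scale stays open, and no evidence on hand bears on the result.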